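The source may hold more compounds than are shown below. What is called first, only, known or untested is meant among the compounds shown, and "the series" means these compounds.

In a functional assay on BV-2 cells (Mus musculus), read by Griess assay (on this read-out higher numbers stand for weaker inhibition and lower numbers for stronger inhibition), compound 1 (`CO[C@]1(C)CCC[C@@H]2[C@@](C)(C[C@H](OC(C)=O)C3=CC(=O)OC3)[C@H](C)C[C@H](OC(C)=O)[C@]21COC(C)=O`) reads > 100000 nM, which is a limit of the assay and not a number. Compound 2 (`CO[C@]1(C)CC[C@@H](OC(C)=O)[C@@H]2[C@@](C)(C[C@H](OC(C)=O)C3=CC(=O)OC3)[C@H](C)C[C@H](OC(C)=O)[C@]21COC(C)=O`) gives 45500 nM. Going by the values given here, the one measured step, an at least 2.1-fold lower number from compound 1 to compound 2 (0.34 log units; beyond the scatter), comes with acetoxy in place of hydrogen on a saturated ring carbon. Compound 3 (`CO[C@]1(C)CCC[C@@H]2[C@@](C)(C[C@H](OC(=O)C(C)C)C3=CC(=O)OC3)[C@H](C)C[C@H](OC(C)=O)[C@]21COC(C)=O`) carries a different change: isopropyl in place of methyl on a carbonyl carbon, so that an acetoxy becomes (isopropylcarbonyl)oxy, (isopropyl in place of methyl on a carbonyl carbon). Among the compounds with values here, no measured step covers this change, so compound 2, with its step of an at least 2.1-fold lower number from compound 1 to compound 2 (0.34 log units; beyond the scatter), offers only a rough guide to size. A modest move towards lower numbers in this assay is expected, and compound 3 may well stay at the limit. The expected shift is an at least 1.4-fold lower number from compound 1 to compound 3 (0.15 log units; that floor lies within the scatter). Compound 3 is estimated at 70000 nM, with an expected range of 30000 nM to 100000 nM.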

Compound 3, half-maximal inhibitory concentration: 27000 nM
Estimate against measurement, compound 3: 2.6-fold (0.41 log units) above; the whole stated range lies above it.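

In this assay there is an at least 3.7-fold lower number from compound 1 to compound 3 (0.56 log units; beyond the scatter), and it shows that this acetoxy is a place where a change on the carbonyl carbon counts: isopropyl in place of methyl there is enough to bring a reading inside the range of the assay. Going by these compounds alone, until this result, only an added acetoxy on a saturated ring carbon had been seen to do so, and the acetoxy already present on the core had not been touched. The reading of compound 1, > 100000 nM, is a limit and not a number, so the step gives only a floor: the limit of > 100000 nM in this assay, at which 1 of the 3 values shown sits.

As far as these compounds go, whether ethyl, tert-butyl or phenyl on the same carbonyl carbon would take the number further than in compound 3 stays open. So does whether the same change on the other acetoxy groups of the core of compound 1 would move it at all.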